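Phenyl for bromo on the shared core: compound 4

The compounds below may be only part of what the source reports. "The series", "measured", "known", "first", "only" and "open" are said of these compounds alone.

Measured in a functional assay on CHO-K1 cells for antagonist activity at Orexin receptor type 2 (Homo sapiens), read by FLIPR and calcium flux; on this read-out higher numbers stand for weaker inhibition and lower numbers for stronger inhibition:
compound 1 `CCc1ccnc(O[C@@H]2CC[C@@H](C)N(C(=O)c3ccccc3-n3nccn3)C2)c1` gives 11 nM
compound 2 `C#Cc1ccnc(O[C@@H]2CC[C@@H](C)N(C(=O)c3ccccc3-n3nccn3)C2)c1` gives 10 nM
compound 3 `C[C@@H]1CC[C@@H](Oc2cc(Br)ccn2)CN1C(=O)c1ccccc1-n1nccn1` gives 10 nM

Compound 3 is level with compound 2 at the digits shown, and the two together sit at the lowest numbers of the three; compound 1 is the furthest away, yet a 1.1-fold lower number from compound 1 to compound 3 (0.04 log units; within the scatter) and no change at the digits printed from compound 2 to compound 3 (within the scatter) both fall within the scatter, as does a 1.1-fold lower number from compound 1 to compound 2 (0.04 log units; within the scatter). The three substituents on the six-membered aromatic ring with 1 nitrogen thus give the same read-out.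

Compound 4 `C[C@@H]1CC[C@@H](Oc2cc(-c3ccccc3)ccn2)CN1C(=O)c1ccccc1-n1nccn1` is yet to be measured. The change is phenyl in place of bromo on an aromatic carbon. For the measured compounds named here, no measured step places a ring at this position; the three steps above exchange small groups and each stayed within the scatter, so they bear only indirectly. On that basis a step in this assay beyond the scatter is not expected in either direction, though the uncertainty is wider than for the measured exchanges. Compound 4 is therefore estimated at 18 nM, expected to lie between 5 nM and 80 nM. For compound 4 the expected step is a 1.8-fold higher number from compound 3 to compound 4 (0.26 log units; within the scatter).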

Compound 4, half-maximal inhibitory concentration: 45 nM
For compound 4 the middle estimate is 2.5-fold (0.40 log units) below the measured one; measured number inside the range.
By their numbers in this assay, from the lowest: compounds 2, 3 and 1 (each within the scatter of the next); then compound 4.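

In this assay, for the compounds shown here, phenyl on the aromatic carbon opposite the ring nitrogen gives a 4.5-fold higher number from compound 3 to compound 4 (0.65 log units; beyond the scatter) and a 4.5-fold higher number from compound 2 to compound 4 (0.65 log units; beyond the scatter) and also a 4.1-fold higher number from compound 1 to compound 4 (0.61 log units; beyond the scatter) as the first steps beyond the scatter. The position therefore does not accept every group alike: bromo, ethynyl and ethyl stay within the scatter of one another, whereas the six-membered aromatic ring of carbon only, with 6 heavy atoms against 1 for bromo, gives weaker inhibition than all three. No supporting data bear on the origin of this loss.

Open, from the compounds shown here alone, is whether the loss belongs to aromatic rings as such or to any group of this size, which a cyclopropyl ring, a cyclohexyl ring or a longer chain such as butyl at this carbon would help separate. Also open, going by these compounds, is whether a phenyl ring carrying an amine or a carboxylic acid would give a different read-out from phenyl itself.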